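Toward a Methoxymethyl Analogue: Cytotoxicity Expectations

The source may hold more compounds than are shown below. What is called first, only, known or untested is meant among the compounds shown, and "the series" means these compounds.

Measured so far:
compound 1, `CC(C)=CCOc1cccc(Nc2ncccn2)c1` — > 100000 nM
compound 2, `CC(C)=CCOc1cc(Nc2nccc(C)n2)ccc1Cl` — < 200 nM

Of the compounds shown here, two have been tested in a functional assay on MT2 cells (Homo sapiens) for cytotoxicity, read by MTT assay; on this read-out higher numbers stand for lower toxicity in this test and lower numbers for higher toxicity in this test. For compound 1 the result is only a limit of the assay, > 100000 nM, so no exact number is known for it; this is the limit named in the limit of > 100000 nM in this assay, at which 1 of the 2 values shown sits. For compound 2 the result is also only a limit, < 200 nM, again without an exact number, and it is the limit named in the limit of < 200 nM in this assay, at which 1 of the 2 values shown sits. On the numbers shown, compound 2 therefore stands at the more toxic end of the two results, while compound 1 stands at the less toxic end, but both rest on limits rather than measured values, and the two compounds differ in more than one place, so no single step between them can be read.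

Compound 3 `COCc1ccnc(Nc2ccc(Cl)c(OCC=C(C)C)c2)n1` differs from compound 2 by methoxy in place of hydrogen on a saturated chain carbon bound to an aromatic carbon. For the measured compounds named here, no measured step of this kind exists here. The step from compound 2 to compound 3 in this assay is expected to be small, a step that the limit leaves unreadable from compound 2 to compound 3, not clearly beyond the usual scatter. Compound 3 is accordingly estimated at 150 nM, within a range from 30 nM to 1500 nM.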

Compound 3, half-maximal cytotoxic concentration: > 25000 nM
Compound 3: a limit, no number (the forecaster's own chance of this, stated with the estimate: 50%); at least 160-fold (2.22 log units) between middle value and limit.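

In this assay, replacing methyl with methoxymethyl, a change on a saturated chain carbon bound to an aromatic carbon, gives an at least 120-fold higher number from compound 2 to compound 3 (2.09 log units; beyond the scatter), a large change that points toward lower toxicity in this test. Compound 1 and compound 2 differ in more than one place, so they could not show that this one change alone can move the read-out this far. Compound 3 gives a limit rather than a number: the limit of > 25000 nM in this assay, at which 1 of the 3 values shown sits.

As far as these compounds go, both ends of this step are limits, so its true size stays open, and so does the question of whether the oxygen of the methoxymethyl group matters or the added chain length alone is enough. An ethyl, hydroxymethyl or aminomethyl group at the same place would help to separate these two readings.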